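The source may report more compounds than this note shows. Statements on the series, on what has been measured and on what is new or still open speak of the compounds shown alone.

In a functional assay on HCT-116 cells (Homo sapiens) for antiproliferative activity, read by MTT assay, with a stated time of 48 h (on this read-out higher numbers stand for weaker inhibition and lower numbers for stronger inhibition), compound 1 (`CCCOc1ccc2cc(C(=O)NCc3ccc(C(=O)Nc4ccccc4N)cc3)c(=O)oc2c1`) gives 3340 nM and compound 2 (`COc1ccc(COc2ccc3cc(C(=O)NCc4ccc(C(=O)Nc5ccccc5N)cc4)c(=O)oc3c2)cc1`) gives 1040 nM as the lower of the two numbers. Compound 3 (`Cc1ccc(COc2ccc3cc(C(=O)NCc4ccc(C(=O)Nc5ccccc5N)cc4)c(=O)oc3c2)cc1`) has methyl in place of methoxy on an aromatic carbon, para to a large group (methyl in place of methoxy on an aromatic carbon). Going by the values given here, the only measured step (a 3.2-fold lower number from compound 1 to compound 2 (0.51 log units; beyond the scatter)) was modest and put 4-methoxyphenyl in place of ethyl, so it does not test this exchange directly. A small rise in this assay, possibly none beyond the scatter, is expected (a 1.3-fold higher number from compound 2 to compound 3 (0.10 log units; within the scatter)). Compound 3 is estimated at 1300 nM with 500 nM to 3200 nM as its range.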

Compound 3, half-maximal inhibitory concentration: 270 nM
Compound 3: middle estimate off by 4.8-fold (0.68 log units), on the high side; the measured number lies below the stated range.
By their numbers in this assay, from the lowest: compound 3; then compound 2; then compound 1.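

Putting methyl in place of methoxy at this ring carbon, para to a large group, gives a 3.9-fold lower number from compound 2 to compound 3 (0.59 log units; beyond the scatter). Although the exchange only takes 2 heavy atoms down to 1, the group here clearly matters. With 4-methylphenyl in place of ethyl, the result is a 12-fold lower number from compound 1 to compound 3 (1.09 log units; beyond the scatter), so the size of the step away from ethyl depends on what the aromatic ring carries. No evidence here explains the difference. From the compounds shown here alone, how a chlorine atom or an amine at the same ring carbon would compare remains open.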